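This account rests on a few compounds, and the source may have more. Where it says the series, first, only, none or still open, it means among the compounds named here.

Working notes on the series. Compound 1 `Oc1cccc(CNc2cc(Br)cc3[nH]ncc23)c1` gives 45% in an assay for inhibition of Indoleamine 2,3-dioxygenase 1 (Homo sapiens), with a stated time of 1 h, tested at 10 uM; a higher number here means more inhibition at the concentration tested (going by the name of the read-out), a lower number less inhibition. Compound 2 `Nc1cccc(CNc2cc(Br)cc3[nH]ncc23)c1` gives 31%, and compound 3 `O=C(O)Nc1cccc(CNc2cc(Br)cc3[nH]ncc23)c1` gives 57%, the highest of the three numbers shown. The steps are a number 14 percentage points lower from compound 1 to compound 2 (beyond the scatter), a number 12 percentage points higher from compound 1 to compound 3 (beyond the scatter) and a number 26 percentage points higher from compound 2 to compound 3 (beyond the scatter).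

Compound 4 `O=C1CCCC(Nc2cccc(CNc3cc(Br)cc4[nH]ncc34)c2)C1` differs from compound 3 in one place: 3-oxocyclohexyl in place of carboxy on a nitrogen on an aromatic ring. The step that bears most directly on this is the one in which carboxy replaced hydrogen on that nitrogen, a number 26 percentage points higher from compound 2 to compound 3 (beyond the scatter); compound 4 gives up the carboxy, and with it the single hydrogen-bond donor of that group, while the entering 3-oxocyclohexyl keeps one hydrogen-bond acceptor. Going by the values given here, no measured step shows a 3-oxocyclohexyl, so the entering group itself is unread. The expectation is a modest loss against compound 3, not as deep as compound 2, giving a number 17 percentage points lower from compound 3 to compound 4 (beyond the scatter). Compound 4 is therefore estimated at 40%, with a range from 20% to 62%.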

Compound 4, a percentage reported as inhibition, at one concentration (the size of the read-out at that concentration, not a potency): 52%
For compound 4 the middle estimate is 12 percentage points below the measured one, within the range that was stated.
By their numbers in this assay, from the lowest: compound 2; then compounds 1, 4 and 3 (each within the scatter of the next, the first and the last beyond it).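

On the nitrogen on an aromatic ring, the carboxy group can give way to 3-oxocyclohexyl, a larger carbocyclic group with no hydrogen-bond donor, with a number 5 percentage points lower from compound 3 to compound 4 (within the scatter) in this assay, so that donor is not needed at this position in these compounds. Two quite different groups now improve on hydrogen at this nitrogen, with a number 26 percentage points higher from compound 2 to compound 3 (beyond the scatter) and a number 21 percentage points higher from compound 2 to compound 4 (beyond the scatter), while the change from hydroxy on the aromatic carbon to (3-oxocyclohexyl)amino gives only a number 7 percentage points higher from compound 1 to compound 4 (within the scatter). Nothing available explains why these two groups read alike.

Going by these compounds, whether the ring carbonyl of 3-oxocyclohexyl contributes remains open, and plain cyclohexyl on the same nitrogen would test it. A methyl group, an acetyl group or a longer alkyl chain there would show how much of the gain over hydrogen survives in smaller or more flexible groups.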